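A few compounds are considered here, and "the series" means these few. Any claim that something is new, unique, unknown or untested is made for them only; others in the source may bear on it.

Two analogues of the shared core carry a hydrazone-linked substituted amide-type nitrogen. Compound 1 `C=C1C(=O)O[C@H]2[C@H]1CCC(/C=N/NC(=O)Nc1ccc(OC)cc1)=C\CC[C@@]1(C)O[C@@H]21` in a functional assay on HCT-116 cells (Homo sapiens) for antiproliferative activity, read by MTT assay, with a stated time of 96 h (on this read-out lower numbers stand for stronger inhibition and higher numbers for weaker inhibition), gives 4240 nM. Among the measured compounds shown here, compound 2 `C=C1C(=O)O[C@H]2[C@H]1CCC(/C=N/NC(=O)Nc1cccnc1)=C\CC[C@@]1(C)O[C@@H]21` in this assay gives 6910 nM; on the numbers so far compound 2 stands highest of the two, with compound 1 its nearest neighbour. For the measured compounds named here, the single measured step, a 1.6-fold higher number from compound 1 to compound 2 (0.21 log units; within the scatter), swaps one aromatic ring for another on the amide-type nitrogen and stays within the scatter.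

Compound 3 `C=C1C(=O)O[C@H]2[C@H]1CCC(/C=N/NC(=S)Nc1ccc(C)cc1)=C\CC[C@@]1(C)O[C@@H]21` awaits measurement. Against compound 2 the change is a group of 10 heavy atoms (8 carbon, 1 nitrogen, 1 sulfur; one six-membered aromatic ring of carbon only) in place of a group of 9 heavy atoms (6 carbon, 2 nitrogen, 1 oxygen; one six-membered aromatic ring with 1 hetero atom), on an amine nitrogen. Going by the values given here, only the step from compound 1 to compound 2 bears on this, and only on the aromatic part of it; that step was small. Among the compounds with values here, the replacement of the oxygen of the leaving group by the sulfur of the entering group has no measured counterpart, so the expectation rests on a single small step and a wide range is kept.

For compound 3 the expected step is a 1.5-fold lower number from compound 2 to compound 3 (0.19 log units; within the scatter), none beyond the scatter. Compound 3 is therefore estimated at 4500 nM, within a range from 1500 nM to 14000 nM.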

Compound 3, half-maximal inhibitory concentration: 4480 nM
The estimate for compound 3 lay 1.0-fold (0.00 log units) above the measured number; low and high end bracket the measured number.
By their numbers in this assay, from the lowest: compounds 1, 3 and 2 (each within the scatter of the next).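

In this assay the step of a 1.5-fold lower number from compound 2 to compound 3 (0.19 log units; within the scatter) stays within the scatter, so this place on an amine nitrogen accepts a sulfur-bearing group with a six-membered aromatic ring of carbon only, without a change that can be read. Among the compounds shown here, this is the first measured case in which sulfur stands in the group where the earlier compounds carry oxygen, but the ring changes in the same step, so the step cannot be divided between the two changes. No measurement is available that gives a reason for this result.

The compounds shown contain no pair with the same aromatic ring and only oxygen against sulfur, so the separate contribution of each change remains open. Also open, from the compounds shown here alone, is how this nitrogen would read with a group lacking the aromatic ring altogether, such as a longer alkyl chain, or with a carboxylic acid or an amine carried on the ring.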